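Replacing the chain carboxy group with a hydroxyethyl arm

The source may report more compounds than this note shows. Statements on the series, on what has been measured and on what is new or still open speak of the compounds shown alone.

The series shares one core, carried in compound 1 `O=C(O)COc1cccc(/C=C/c2nc(-c3ccccc3)c(-c3ccccc3)o2)c1`, compound 2 `CCOC(=O)C(Cc1cccc(OCC(=O)O)c1OC)c1nc(-c2ccccc2)c(-c2ccccc2)o1` and compound 3 `O=C(O)COc1cccc(CC(C(=O)O)c2nc(-c3ccccc3)c(-c3ccccc3)o2)c1`, and is followed in a functional assay for inhibition, with Homo sapiens as the target; on this read-out lower numbers stand for stronger inhibition and higher numbers for weaker inhibition. In this assay compound 1 gives 13000 nM, compound 2 gives 1180 nM and compound 3 gives 14000 nM. Compound 3 thus has the highest of the three numbers; its nearest neighbour is compound 1, whose number lies within the scatter of that of compound 3, while compound 2 stands furthest off with a number beyond the scatter. Compound 4 `O=C(O)COc1cccc(CC(CCO)c2nc(-c3ccccc3)c(-c3ccccc3)o2)c1` differs from compound 3 in a single place: 2-hydroxyethyl in place of carboxy on a saturated chain carbon bound to an aromatic carbon and a saturated chain carbon. For the measured compounds named here, no step between measured compounds isolates this change, so the expectation rests on the one direction the data offer, where compound 2, without a free carboxy on that chain carbon, shows the lower number. The step from compound 3 to compound 4 is therefore expected to be moderate and toward stronger inhibition, a 2.8-fold lower number from compound 3 to compound 4 (0.45 log units; beyond the scatter). In this assay compound 4 is estimated at 5000 nM, within a range from 1500 nM to 16000 nM.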

Compound 4, half-maximal inhibitory concentration: 2920 nM
The estimate for compound 4 lay 1.7-fold (0.23 log units) above the measured number; the range from low to high includes it.
By their numbers in this assay, from the lowest: compound 2; then compound 4; then compounds 1 and 3 (each within the scatter of the next).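

In this assay, the saturated chain carbon bound to an aromatic carbon and a saturated chain carbon proves not to need its carboxy group, since 2-hydroxyethyl in its place gives a 4.8-fold lower number from compound 3 to compound 4 (0.68 log units; beyond the scatter) and so moves toward stronger inhibition. For the compounds shown here, until this step, no two compounds differed at this carbon alone, so the earlier numbers could not show what a change there does by itself. Nothing measured here offers an explanation for the step.

The compounds shown leave open whether the hydroxy end of the new arm matters or the carbon chain alone suffices, which an ethyl group, a 3-hydroxypropyl chain or a 2-aminoethyl arm on this carbon would test. Going by these compounds, it also remains open how much the ethyl ester and the methoxy group of compound 2 each contribute to its number.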